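The compounds below may be only part of what the source reports. "The series", "measured", "known", "first", "only" and "open" are said of these compounds alone.

Measured compounds:
- compound 1, `COc1cc(-c2ccnc3cc(-c4ccc(F)cc4)nn23)cc(OC)c1OC`: 1280 nM
- compound 2, `COc1cc(-c2ccnc3cc(-c4c[nH]c5ccccc45)nn23)cc(OC)c1OC`: 85 nM
- compound 3, `COc1cc(-c2ccnc3cc(-c4cccc(C#N)c4)nn23)cc(OC)c1OC`: > 10000 nM

All three share one core and differ only in the aromatic group attached to it. In a functional assay on MCF7 cells (Homo sapiens) for inhibition, read by CCK-8 assay, with a stated time of 48 h (a lower number here means a stronger inhibitor, a higher number a weaker inhibitor), compound 1 has the higher of the two plain numbers; compound 2 is the nearer, and the step of a 15-fold lower number from compound 1 to compound 2 (1.18 log units; beyond the scatter) is the one real improvement seen. Compound 3 sits at a limit of this assay, (the limit of > 10000 nM in this assay, at which 1 of the 3 values shown sits), not at a number. Against that limit the step of an at least 7.8-fold higher number from compound 1 to compound 3 (0.89 log units; beyond the scatter) is a worsening, and the step of an at least 110-fold higher number from compound 2 to compound 3 (2.07 log units; beyond the scatter) is a larger one.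

Compound 4, `COc1cc(-c2ccnc3cc(-c4ccc5c(ccn5C)c4)nn23)cc(OC)c1OC`, is not yet measured. It differs from compound 1 in one place: 1-methyl-1H-indol-5-yl in place of 4-fluorophenyl on an aromatic carbon. For the measured compounds named here, only the step from compound 1 to compound 2 bears on this change, since it too puts a bicyclic indole in place of the 4-fluorophenyl, though compound 2 carries the indole through a different ring atom and keeps a hydrogen-bond donor that compound 4 lacks. A lower number than compound 1 is therefore expected, but with less confidence and likely a smaller step than a 15-fold lower number from compound 1 to compound 2 (1.18 log units; beyond the scatter). The estimated step is a 3.7-fold lower number from compound 1 to compound 4 (0.56 log units; beyond the scatter). For compound 4 the expected value in this assay is 350 nM, within the range 80 nM to 1500 nM.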

Compound 4, half-maximal inhibitory concentration: 3 nM
For compound 4 the middle estimate is 120-fold (2.07 log units) above the measured one; the whole stated range lies above it.
By their numbers in this assay, from the lowest: compound 4; then compound 2; then compound 1. At a limit, above all of these: compound 3.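

For the compounds shown here, this position on the shared core is far more sensitive to the choice of aromatic group than the earlier compounds showed, as a 430-fold lower number from compound 1 to compound 4 (2.63 log units; beyond the scatter) in this assay is well beyond the earlier gain from the 1H-indol-3-yl group, and a 28-fold lower number from compound 2 to compound 4 (1.45 log units; beyond the scatter) shows that the two indole-bearing compounds are themselves far apart. Since 1-methyl-1H-indol-5-yl has 0 hydrogen-bond donors, compound 4 also shows that a donor on this group is not required for a low number, and the full spread of the series now reaches an at least 3300-fold lower number from compound 3 to compound 4 (3.52 log units; beyond the scatter). That last step is only a lower bound, as the value of compound 3 is a limit and not a number: the limit of > 10000 nM in this assay, at which 1 of the 4 values shown sits.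

Compound 4 differs from compound 2 both in the methyl on the indole nitrogen and in how the indole is joined to the core, and the compounds shown cannot separate these two changes. As far as these compounds go, how the indole would fare with an amine or a carboxylic acid on its six-membered ring also remains open.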